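From 4-aminophenyl to 4-nitrophenyl: working notes

The source may report more compounds than this note shows. Statements on the series, on what has been measured and on what is new or still open speak of the compounds shown alone.

Among the measured compounds shown here, in a physicochemical assay for lipophilicity, read by LC-MS, using the shake flask method, in phosphate buffer, measured as octanol-water partition, with a stated time of 2 h, at pH 7.4 (a lower number here means a more polar compound, a higher number a more lipophilic compound), compound 2 (`Nc1ccc(-n2cc(CO[C@H]3O[C@H](CO)[C@@H](O)[C@H](O)[C@@H]3O)nn2)cc1`) gives 0.2 as the only number so far. Compound 1 (`O=C(O)c1cncc(-n2cc(CO[C@H]3O[C@H](CO)[C@@H](O)[C@H](O)[C@@H]3O)nn2)c1`) carries "not determined" (no result reported) and so offers no comparison. Compound 3 (`O=[N+]([O-])c1ccc(-n2cc(CO[C@H]3O[C@H](CO)[C@@H](O)[C@H](O)[C@@H]3O)nn2)cc1`) awaits measurement and differs from compound 2 in one place (nitro in place of amino on an aromatic carbon): nitro in place of amino on an aromatic carbon, para to a large group. For the measured compounds named here, no measured pair calibrates this change, so the expectation rests on the structures alone. The expected step in this assay is upward and beyond the usual scatter, estimated at a number 0.50 log units higher from compound 2 to compound 3 (beyond the scatter) on the structural change alone. Compound 3 is expected at 0.7 (0.3 to 1.1).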

Compound 3, distribution coefficient: -0.16
The estimate for compound 3 lay 0.86 log units above the measured number; measured number below the stated range.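

In this assay, among the compounds shown here, nitro in place of amino on an aromatic carbon, para to a large group, gives a number 0.36 log units lower from compound 2 to compound 3 (beyond the scatter) as the first measured step. This position is therefore not silent in this read-out, although the direction rests on a single pair. Nothing measured here accounts for the direction of the step. Going by these compounds, whether a nitrile, a methoxy group or a longer chain at this position would move the number the same way remains open. So does whether the step would hold on any core other than the one shared by these compounds.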